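Swapping Dimethylamino for Phenyl on a Shared Amide Core

The source may report more compounds than this note shows. Statements on the series, on what has been measured and on what is new or still open speak of the compounds shown alone.

Compound 3 `CCOC(=O)CCCCCOc1cccc(CN(C(=O)c2ccc(-c3cccc(N(C)C)c3)cc2)C(C)C)c1` carries a dimethylamino group and an ethyl ester. In an ADME assay on HEK293 cells (Homo sapiens) for cytotoxicity, read by CellTiter-Glo and resazurin assay, with a stated time of 72 h (a lower number here means that less compound is needed, a higher number that more compound is needed for the effect), compound 3 gives only a limit, > 26000 nM. Two related compounds have been tested the same way. Compound 1 `CC(C)N(Cc1cccc(OCCCCCC(=O)O)c1)C(=O)c1ccc(-c2cccc(N(C)C)c2)cc1` carries a carboxylic acid where compound 3 carries the ethyl ester; in this assay compound 1 gives a limit of > 26000 nM. Compound 2 `CC(C)N(Cc1cccc(OCCCCCC(=O)O)c1)C(=O)c1ccc(-c2cccc(S(C)(=O)=O)c2)cc1` carries methylsulfonyl where compound 1 carries dimethylamino; in this assay compound 2 also gives a limit of > 26000 nM. The step that the two limits leave unreadable from compound 1 to compound 2 cannot be read, and neither can a step that the two limits leave unreadable from compound 1 to compound 3, as shown by the limit of > 26000 nM in this assay, at which 3 of the 3 values shown sit. Compound 4 `CCOC(=O)CCCCCOc1cccc(CN(C(=O)c2ccc(-c3cccc(-c4ccccc4)c3)cc2)C(C)C)c1` differs from compound 3 in one place: phenyl in place of dimethylamino on an aromatic carbon. Among the compounds with values here, no measured step shows what replacing dimethylamino with phenyl does here. Because every value sits at the limit of > 26000 nM in this assay, at which 3 of the 3 values shown sit, compound 4 is expected to stay there as well, an expected step that the limit leaves unreadable from compound 3 to compound 4. The estimate for compound 4 in this assay is 30000 nM, with a range from 10000 nM to 100000 nM.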

Compound 4, half-maximal effective concentration: > 26000 nM
Compound 4: no number, only a limit (the forecaster's own chance of this, stated with the estimate: 80%); the middle value lies beyond the limit too.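

Compound 4 gives only a limit of > 26000 nM in this assay and compound 3 also gives only a limit, so the change from compound 3 to compound 4 cannot be read. Still open is how much of any compound shown is needed in this assay for the effect, and whether any of these changes alters that amount.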